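The source may hold more compounds than are shown below. What is called first, only, known or untested is meant among the compounds shown, and "the series" means these compounds.

Measured in a functional assay on HepG2 cells (Homo sapiens) for cytotoxicity, read by MTT assay, with a stated time of 48 h; on this read-out higher numbers stand for weaker inhibition and lower numbers for stronger inhibition:
- compound 1 `CCC(=O)N1N=C(C)CC1c1cc(Br)ccc1O`: "not active" (no number reported)
- compound 2 `CC1=NN(C(=O)c2ccc(C)cc2)C(c2cc(Br)ccc2O)C1`: 23200 nM
- compound 3 `CC1=NN(C(=O)CCc2ccccc2)C(c2cc(Br)ccc2O)C1`: 17900 nM

Among the compounds with values here, compound 3 has one numerical neighbour, and the two stand level: the only measured step is a 1.3-fold lower number from compound 2 to compound 3 (0.11 log units; within the scatter). That step exchanges one ring-bearing group for another on the carbonyl carbon, so it bears on the next change only indirectly.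

Compound 4 `C=CCN(CC=C)CC(=O)N1N=C(C)CC1c1cc(Br)ccc1O` departs from compound 3 in a different way: diallylamino in place of benzyl on a saturated chain carbon bound to a carbonyl carbon. Within the data shown here, this removes the aromatic ring from that side of the molecule, and no measured step covers such an exchange. The nearest hint is compound 1, also without a ring in the group on the carbonyl carbon, which gives "not active" (no number reported) in this assay. A modest shift toward a higher number is therefore expected, with a real chance of no number at all. The estimate implies a 1.5-fold higher number from compound 3 to compound 4 (0.16 log units; within the scatter). For compound 4 the estimated value is 26000 nM, with an expected range of 11000 nM to 60000 nM.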

Compound 4, half-maximal inhibitory concentration: 7870 nM
Compound 4: middle estimate off by 3.3-fold (0.52 log units), on the high side; measured number below the stated range.
By their numbers in this assay, from the lowest: compound 4; then compounds 3 and 2 (each within the scatter of the next).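

In this assay, this position accepts a group without an aromatic ring: diallylamino in place of benzyl gives a 2.3-fold lower number from compound 3 to compound 4 (0.36 log units; beyond the scatter), and the wider exchange of (diallylamino)methyl for 4-methylphenyl on the carbonyl carbon gives a 2.9-fold lower number from compound 2 to compound 4 (0.47 log units; beyond the scatter). Lacking a ring on that side therefore does not by itself remove activity, as compound 4 carries none and still gives a number, whereas compound 1, also without a ring in the group on the carbonyl carbon, gives "not active" (no number reported). Nothing measured here speaks to the reason for this shift.

From the compounds shown here alone, whether the amine nitrogen or the double bonds go with the lower number stays open, and a diethylamino or morpholino group at the same place would separate the two. Equally open, going by these compounds, is whether a longer chain carrying the diallylamino group would hold the number.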